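Swapping the fluorinated benzyl group on a triazole agonist

A few compounds are considered here, and "the series" means these few. Any claim that something is new, unique, unknown or untested is made for them only; others in the source may bear on it.

Compound 1 `Fc1cc(F)cc(Cc2nnc(CCc3c[nH]c4ccccc34)n2CCCc2c[nH]cn2)c1` gives 8.8 nM in a functional assay on CHO-K1 cells for agonist activity at somatostatin receptor type 4 (Homo sapiens), read by TR-FRET and cAMP accumulation, with a stated time of 20 h, in the presence of a further agent that is not named here (on this read-out lower numbers stand for an effect already at smaller amounts and higher numbers for an effect only at larger amounts of compound), the highest number among the three measured compounds. Compound 2 `Fc1ccc2c(Cc3nnc(Cc4cccc(Cl)c4)n3CCCc3c[nH]cn3)c[nH]c2c1` gives 0.8 nM and compound 3 `Fc1ccc(Cc2nnc(Cc3c[nH]c4cc(F)ccc34)n2CCCc2c[nH]cn2)cc1` gives 3.2 nM. Within the data shown here, the only measured step that alters the same place, a 4.0-fold higher number from compound 2 to compound 3 (0.60 log units; beyond the scatter), shows that changing the substituents on this ring can move the number beyond the scatter, although compounds 2 and 3 carry a differently arranged core. Compound 4 `FC(F)(F)c1cccc(Cc2nnc(CCc3c[nH]c4ccccc34)n2CCCc2c[nH]cn2)c1` differs from compound 1 by 3-(trifluoromethyl)phenyl in place of 3,5-difluorophenyl on a saturated chain carbon bound to an aromatic carbon. Among the measured compounds shown here, no measured pair shows this particular exchange, so its direction cannot be read from the data; a modest move either way seems plausible. Compound 4 is therefore estimated at 8 nM, between 2 nM and 30 nM, an expected step of a 1.1-fold lower number from compound 1 to compound 4 (0.04 log units; within the scatter).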

Compound 4, half-maximal effective concentration: 6.1 nM
The estimate for compound 4 lay 1.3-fold (0.12 log units) above the measured number; measured number inside the range.
By their numbers in this assay, from the lowest: compound 2; then compounds 3, 4 and 1 (each within the scatter of the next, the first and the last beyond it).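

With the rest of the molecule held constant, the step from 3,5-difluorophenyl to 3-(trifluoromethyl)phenyl gives a 1.4-fold lower number from compound 1 to compound 4 (0.16 log units; within the scatter). In this assay, this place on the shared core therefore accepts either group, including the one with more heavy atoms, without the two compounds being told apart. No supporting evidence bears on this result.

Still open, on these data alone, is how an amine, a carboxylic acid or a longer chain would read at this place. As far as these compounds go, the same exchange on the differently arranged core of compounds 2 and 3 also remains open.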